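The source may hold more compounds than are shown below. What is called first, only, known or untested is meant among the compounds shown, and "the series" means these compounds.

For the measured compounds named here, in a functional assay on FaDu cells (Homo sapiens) for cytotoxicity, read by MTT assay, with a stated time of 72 h (on this read-out lower numbers stand for higher toxicity in this test and higher numbers for lower toxicity in this test), three compounds have numbers so far. Compound 1 (`CCn1cc(C(=O)C(=O)Nc2ccnc(OC)c2)c2ccccc21`) gives 4180 nM, compound 2 (`COc1ccc(NC(=O)C(=O)c2cn(C(C)C)c3ccccc23)nn1`) gives 2270 nM, and compound 3 (`COc1nsc(NC(=O)C(=O)c2cn(C(C)C)c3ccccc23)n1`) gives 10400 nM, the highest of the three numbers and so the lowest toxicity in this test.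

Compound 4 (`COc1cc(NC(=O)C(=O)c2cn(C(C)C)c3ccccc23)ccn1`) is still unmeasured. It has 2-methoxypyridin-4-yl in place of 3-methoxy-1,2,4-thiadiazol-5-yl on an amide-type nitrogen.

Going by the values given here, one measured step bears directly on this change. Putting the same 3-methoxy-1,2,4-thiadiazol-5-yl in place of 6-methoxypyridazin-3-yl gave a 4.6-fold higher number from compound 2 to compound 3 (0.66 log units; beyond the scatter), a modest step beyond the scatter. Compound 1 also carries 2-methoxypyridin-4-yl on its amide-type nitrogen and gives 4180 nM, though its core is not identical to that of compound 3.

Removing the thiadiazolyl group is therefore expected to bring a modest step towards a lower number in this assay. The estimated change is a 3.0-fold lower number from compound 3 to compound 4 (0.47 log units; beyond the scatter). Compound 4 is expected at 3500 nM, with an estimated range from 1500 nM to 8000 nM.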

Compound 4, concentration lethal to 50% of the cells: 1750 nM
Compound 4: middle estimate off by 2.0-fold (0.30 log units), on the high side, and the stated range covers the measured number.
By their numbers in this assay, from the lowest: compounds 4, 2 and 1 (each within the scatter of the next, the first and the last beyond it); then compound 3.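

In this assay, the amide-type nitrogen now carries three different groups on the same core: a 5.9-fold lower number from compound 3 to compound 4 (0.77 log units; beyond the scatter) sets 3-methoxy-1,2,4-thiadiazol-5-yl apart, whereas a 1.3-fold lower number from compound 2 to compound 4 (0.11 log units; within the scatter) shows that 2-methoxypyridin-4-yl and 6-methoxypyridazin-3-yl cannot be told apart here. The result also shows that this position is not the only one that matters: with methyl in place of hydrogen on a saturated chain carbon bound to an aromatic nitrogen and a saturated chain carbon, the data give a 2.4-fold lower number from compound 1 to compound 4 (0.38 log units; beyond the scatter). Nothing measured here explains either difference.

Still open, from the compounds shown here alone, is whether an amine in place of the methoxy on 2-methoxypyridin-4-yl would keep the number of compound 4. Also open, going by these compounds, is how a longer chain, such as butyl, on the aromatic nitrogen would read.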